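This account rests on a few compounds, and the source may have more. Where it says the series, first, only, none or still open, it means among the compounds named here.

Measured compounds:
- compound 1, `Cn1c(=O)c(S(=O)(=O)Cc2ccc(F)cc2F)cc2cnc(Nc3ccc4[nH]ccc4c3)nc21`, gives 1000 nM in a functional assay on K562 cells (Homo sapiens) for inhibition, read by trypan blue exclusion, with a stated time of 72 h; a higher number here means a weaker inhibitor, a lower number a stronger inhibitor
- compound 2, `Cc1ccc(S(=O)(=O)c2cc3cnc(Nc4cnc5[nH]ccc5c4)nc3n(C)c2=O)cc1`, gives 15000 nM in this assay

Compound 1 has the lowest number of the two measured compounds in this assay. Its nearest neighbour is compound 2, whose value lies well beyond the scatter from that of compound 1, so compound 1 is the stronger inhibitor of the pair. Compound 2 differs from compound 1 in more than one place. The two values alone do not show how much of the gap goes with each difference.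

Compound 3, `Cn1c(=O)c(S(=O)(=O)c2ccc(N)cc2F)cc2cnc(Nc3ccc4[nH]ccc4c3)nc21`, has not yet been measured. It differs from compound 1 in one place: 4-amino-2-fluorophenyl in place of 2,4-difluorobenzyl on a sulfonyl sulfur. Within the data shown here, no measured pair isolates such a change here, so the size of the step is open. On the basis of the two values alone, the step is expected to be small, toward a weaker inhibitor or within the scatter, and the expected step is a 1.5-fold higher number from compound 1 to compound 3 (0.18 log units; within the scatter). Compound 3 is thus estimated to give 1500 nM in this assay, with a likely range from 400 nM to 6000 nM.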

Compound 3, half-maximal inhibitory concentration: 1500 nM
Estimate against measurement, compound 3: no gap at the digits printed, and the stated range covers the measured number.
By their numbers in this assay, from the lowest: compounds 1 and 3 (each within the scatter of the next); then compound 2.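

Among these compounds, with the core of compound 1 held fixed, putting 4-amino-2-fluorophenyl in place of 2,4-difluorobenzyl on a sulfonyl sulfur gives a 1.5-fold higher number from compound 1 to compound 3 (0.18 log units; within the scatter) in this assay and is the first single-place change that can be read. The exchange therefore brings in a hydrogen-bond donor and a hydrogen-bond acceptor, removes a fluorine and replaces a benzyl group with a phenyl group, yet the two numbers stay within the scatter, so this position accepts at least these two quite different groups without a readable change in this measurement. Nothing on hand gives a reason for this outcome.

On these data alone, the step changes the benzyl link and the ring substituents together, so a 2,4-difluorophenyl or a 4-amino-2-fluorobenzyl group on the same sulfonyl sulfur would be needed to tell their parts apart, and whether the outcome would hold for a carboxylic acid or a longer chain there remains open. As far as these compounds go, how much of the gap to compound 2 goes with each place in which it differs also remains open.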